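From a Urea Back to a Plain Benzamide

The source may report more compounds than this note shows. Statements on the series, on what has been measured and on what is new or still open speak of the compounds shown alone.

Going by the values given here, compound 2 `COc1cc(-c2nn(-c3cccc(NC(=O)Nc4ccc(Cl)c(C(F)(F)F)c4)c3)cc2-c2ccncc2)ccc1Cl` is the only compound here with a definite number: in a functional assay on OVCAR-8 cells (Homo sapiens) for inhibition, read by sulforhodamine B assay, with a stated time of 48 h (on this read-out lower numbers stand for stronger inhibition of growth and higher numbers for weaker inhibition of growth), compound 2 gives 5870 nM. Compound 1 `COc1cc(-c2nn(-c3cccc(NC(=O)c4cccc(C(F)(F)F)c4)c3)cc2-c2ccncc2)ccc1Cl` reaches only a limit of this assay, > 50000 nM. That value is one of the limits shown, (the limit of > 50000 nM in this assay, at which 1 of the 2 values shown sits). The measured step of an at least 8.5-fold lower number from compound 1 to compound 2 (0.93 log units; beyond the scatter) shows how much the urea gained. Compound 3 `COc1cc(-c2nn(-c3cccc(NC(=O)c4ccccc4)c3)cc2-c2ccncc2)ccc1Cl` differs from compound 2 by phenyl in place of (4-chloro-3-(trifluoromethyl)phenyl)amino on a carbonyl carbon, returning to an amide like that of compound 1, so the expected step runs the other way and about as large, most likely back to a limit. Compound 3 is estimated at 40000 nM, with a range from 10000 nM to 120000 nM. The expected change is a 6.8-fold higher number from compound 2 to compound 3 (0.83 log units; beyond the scatter).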

Compound 3, concentration for total growth inhibition: > 100000 nM
Compound 3: no number, only a limit; the forecaster's own chance of this, stated with the estimate: 60%; middle value at least 2.5-fold (0.39 log units) from the limit.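

Putting phenyl in place of (4-chloro-3-(trifluoromethyl)phenyl)amino on the carbonyl carbon gives an at least 17-fold higher number from compound 2 to compound 3 (1.23 log units; beyond the scatter), so among these three compounds, only the urea compound 2 has a definite number. In this assay compound 3 reaches only a limit of the assay: the limit of > 100000 nM in this assay, at which 1 of the 3 values shown sits. Compound 1 and compound 3 both stand at limits, so the step between them, hydrogen in place of trifluoromethyl, cannot be read. Still open, from the compounds shown here alone, is whether the urea link or the groups on its ring matter more, and how a plain phenyl urea or a nitrile on that ring would behave.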